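Replacing an arylamino group with dipropylamino

A few compounds are considered here, and "the series" means these few. Any claim that something is new, unique, unknown or untested is made for them only; others in the source may bear on it.

Of the compounds shown here, three on one shared core have been measured in a functional assay on MCF7 cells (Homo sapiens) for inhibition, read by sulforhodamine B assay (a higher number here means a weaker inhibitor, a lower number a stronger inhibitor), so far. Compound 1 `O=C1C=C(NCc2ccccc2)C(=O)c2c1nc1n2[C@H]2OC[C@@H](O)[C@H]2OC1` gives > 8000 nM as its result, which is a limit of the assay and not a number. Compound 2 `O=C1C=C(Nc2ccccc2F)C(=O)c2c1nc1n2[C@H]2OC[C@@H](O)[C@H]2OC1` gives 3640 nM and compound 3 `Cc1ccc(NC2=CC(=O)c3nc4n(c3C2=O)[C@H]2OC[C@@H](O)[C@H]2OC4)cc1C` gives 2080 nM as true numbers. Compound 3 therefore stands level with compound 2, since the step between them is a 1.8-fold lower number from compound 2 to compound 3 (0.24 log units; within the scatter) and separates neither. Both stand apart from the benzyl compound, with an at least 2.1-fold lower number from compound 1 to compound 2 (0.34 log units; beyond the scatter) and an at least 3.8-fold lower number from compound 1 to compound 3 (0.58 log units; beyond the scatter) as the steps.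

Compound 4 `CCCN(CCC)C1=CC(=O)c2nc3n(c2C1=O)[C@H]1OC[C@@H](O)[C@H]1OC3` carries dipropylamino in place of (3,4-dimethylphenyl)amino on a double-bonded ring carbon, and the difference is dipropylamino in place of (3,4-dimethylphenyl)amino on a double-bonded ring carbon in full. Within the data shown here, no measured compound carries a group of this kind, so the estimate is an extrapolation. The nearest guide is compound 1, which lacks an aryl group on the amine nitrogen, and an at least 3.8-fold lower number from compound 1 to compound 3 (0.58 log units; beyond the scatter) read backwards points to a weaker result for compound 4. The step expected in this assay is therefore a 2.9-fold higher number from compound 3 to compound 4 (0.46 log units; beyond the scatter) in the direction of a higher number. Compound 4 could also end at the limit of > 8000 nM in this assay, at which 1 of the 3 values shown sits, instead of a true number. Compound 4 is estimated at 6000 nM with an expected range from 2500 nM to 15000 nM in this estimate.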

Compound 4, half-maximal inhibitory concentration: > 16000 nM
Compound 4: a limit, no number; the forecaster's own chance of this, stated with the estimate: 40%; at least 2.6-fold (0.42 log units) between middle value and limit.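

Compound 4 gives no number in this assay, only a limit: the limit of > 16000 nM in this assay, at which 1 of the 4 values shown sits. Even so, that limit is enough to place it apart from both arylamino compounds, with an at least 7.6-fold higher number from compound 3 to compound 4 (0.88 log units; beyond the scatter) and an at least 4.3-fold higher number from compound 2 to compound 4 (0.64 log units; beyond the scatter), so on the double-bonded ring carbon, dipropylamino is clearly separated from (3,4-dimethylphenyl)amino and (2-fluorophenyl)amino in a way that the earlier compounds, which all kept an amine hydrogen and an aromatic ring, could not show. Compound 1 is also held at a limit, and the step from it to compound 4 cannot be read, which leaves benzylamino and dipropylamino unordered: the limit of > 8000 nM in this assay, at which 1 of the 4 values shown sits.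

The change removes the six-membered aromatic ring and the hydrogen-bond donor together, so the compounds shown cannot say which of the two loses the activity, or whether the propyl chains themselves play any part. Propylamino, which keeps the amine hydrogen without an aromatic ring, and methyl(phenyl)amino, which keeps the aromatic ring without that hydrogen, would pull these two changes apart on the shared core.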